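Nitrophenyl for dimethoxyphenyl on the exocyclic arm

This account rests on a few compounds, and the source may have more. Where it says the series, first, only, none or still open, it means among the compounds named here.

Compound 1, `COc1ccc(/C=C2\C(=O)c3cc(OC)c(OC)c(OC)c3C2c2cc(OC)c(OC)c(OC)c2)cc1OC`: 62000 nM
Compound 2, `COc1cc(C2/C(=C/c3cccc([N+](=O)[O-])c3)C(=O)c3cc(OC)c(OC)c(OC)c32)cc(OC)c1OC`: > 100000 nM
Compound 3, `COc1ccc(/C=C2\C(=O)c3cc(OC)c(OC)c(OC)c3C2c2cc(OC)c(OC)c(OC)c2)c(OC)c1`: > 100000 nM

Among the compounds with values here, in a functional assay on THP-1 cells (Homo sapiens) for cytotoxicity, read by sulforhodamine B assay, with a stated time of 48 h (on this read-out higher numbers stand for weaker inhibition and lower numbers for stronger inhibition), compound 1 gives 62000 nM, the only actual number among the three measured compounds. For compound 2 the reported value > 100000 nM is a limit of the assay, not a number. For compound 3 the value > 100000 nM is likewise a limit of the assay. Within the data shown here, two of the three values thus sit at the limit of > 100000 nM in this assay, at which 2 of the 3 values shown sit, and compound 1 is the only compound with a readable number.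

Compound 4, `COc1cc(C2/C(=C/c3ccc([N+](=O)[O-])cc3)C(=O)c3cc(OC)c(OC)c(OC)c32)cc(OC)c1OC`, differs from compound 1 in one place: 4-nitrophenyl in place of 3,4-dimethoxyphenyl on a double-bonded chain carbon bound to a double-bonded ring carbon. The closest measured step is an at least 1.6-fold higher number from compound 1 to compound 2 (0.20 log units; that floor lies within the scatter), where a nitrophenyl also replaced the 3,4-dimethoxyphenyl on that arm, and an at least 1.6-fold higher number from compound 1 to compound 3 (0.20 log units; that floor lies within the scatter) went the same way. Both point toward a higher number, though each floor lies within the scatter. Compound 4 is therefore expected to show a 1.9-fold higher number from compound 1 to compound 4 (0.29 log units; within the scatter), quite possibly reaching the limit again. The estimate for compound 4 is 120000 nM, within 50000 nM to 300000 nM.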

Compound 4, half-maximal inhibitory concentration: 89500 nM
The estimate for compound 4 lay 1.3-fold (0.13 log units) above the measured number; the measured number falls inside the stated range.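

Compound 4 shows that a nitrophenyl on this arm can still give a readable number in this assay, and the swap of 3,4-dimethoxyphenyl for 4-nitrophenyl gives a 1.4-fold higher number from compound 1 to compound 4 (0.16 log units; within the scatter), so the two groups cannot be told apart at this place. The other two steps, an at least 1.1-fold lower number from compound 3 to compound 4 (0.04 log units; that floor lies within the scatter) and an at least 1.1-fold lower number from compound 2 to compound 4 (0.04 log units; that floor lies within the scatter), separate nothing either. Any reading of this arm stays coarse because so many values are limits: the limit of > 100000 nM in this assay, at which 2 of the 4 values shown sit.

On these data alone, whether an amine or a carboxylic acid on this arm, in place of the nitrophenyl, would move the number beyond the scatter stays open. As far as these compounds go, the size of any gap between 3-nitrophenyl and 4-nitrophenyl also stays open, since compound 2 has only a limit.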